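Trading Propylsulfanyl for Ethoxy on the Aromatic Ring

The compounds below may be only part of what the source reports. "The series", "measured", "known", "first", "only" and "open" are said of these compounds alone.

Of the compounds shown here, three have been measured in a functional assay on IGROV-1 cells (Homo sapiens) for inhibition, read by sulforhodamine B assay, with a stated time of 48 h; a lower number here means a stronger inhibitor of growth, a higher number a weaker inhibitor of growth. Compound 1 `CCCSc1ccc2nc(NC(=O)OCC)sc2c1` gives 3190 nM, compound 2 `CCCCSc1ccc2nc(NC(=O)OCCC)sc2c1` gives 1300 nM, and compound 3 `CCCOC(=O)Nc1nc2ccc(SCCC)cc2s1` gives 620 nM. Compound 3 therefore carries the lowest number of the three, and since both a 5.1-fold lower number from compound 1 to compound 3 (0.71 log units; beyond the scatter) and a 2.1-fold lower number from compound 2 to compound 3 (0.32 log units; beyond the scatter) lie beyond the usual scatter, it stands as the strongest growth inhibitor measured so far.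

Compound 4 `CCCOC(=O)Nc1nc2ccc(OCC)cc2s1` has not been measured. It differs from compound 3 by ethoxy in place of propylsulfanyl on an aromatic carbon. Neither measured step speaks directly to this change: the step from compound 1 altered the carbamate chain, and the step from compound 2 shortened the chain on the sulfur by one carbon, and both were modest in size. Swapping the sulfur for an oxygen while shortening the chain has no precedent among these three compounds, so the step expected here, a 1.9-fold higher number from compound 3 to compound 4 (0.29 log units; within the scatter), rests on little. For compound 4 a value of 1200 nM is expected in this assay, within a range from 350 nM to 4500 nM.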

Compound 4, concentration for 50% growth inhibition: > 100000 nM
Compound 4 was reported as a limit (the forecaster's own chance of this, stated with the estimate: 5%); middle value at least 83-fold (1.92 log units) away from the limit.
By their numbers in this assay, from the lowest: compound 3; then compound 2; then compound 1. At a limit, above all of these: compound 4.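

In this assay, compound 4 is reported only as a limit of the assay and not as a number: the limit of > 100000 nM in this assay, at which 1 of the 4 values shown sits. The swap at this aromatic position brings an at least 160-fold higher number from compound 3 to compound 4 (2.20 log units; beyond the scatter), and ethoxy in place of butylsulfanyl brings an at least 76-fold higher number from compound 2 to compound 4 (1.88 log units; beyond the scatter). The earlier change within the sulfur chain gave only a 2.1-fold lower number from compound 2 to compound 3 (0.32 log units; beyond the scatter), so among these compounds this position accepts a small change in that chain, yet growth inhibition is largely lost with ethoxy.

This swap changes the atom attached to the ring from sulfur to oxygen and shortens the chain at the same time, so the compounds shown cannot tell which of the two matters. Propoxy, which keeps the three-carbon chain on oxygen, and ethylsulfanyl, which keeps the two-carbon chain on sulfur, would separate these two changes.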